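Working notes: a second chloro on compound 3

This account rests on a few compounds, and the source may have more. Where it says the series, first, only, none or still open, it means among the compounds named here.

Measured in a physicochemical assay for lipophilicity, measured as octanol-water partition, at pH 7.4; a lower number here means a more polar compound, a higher number a more lipophilic compound:
- compound 1 `O=C(N[C@H]1CN(S(=O)(=O)c2ccccc2)C[C@@H]1C(=O)N[C@H]1CCCNC1)c1cc(-c2ccccc2)on1` gives 1.3
- compound 2 `O=C(N[C@H]1CN(S(=O)(=O)c2ccccc2)C[C@@H]1C(=O)N[C@H]1CCCNC1)c1nnc(-c2ccc(F)cc2)s1` gives 1
- compound 3 `O=C(N[C@H]1CN(S(=O)(=O)c2ccccc2)C[C@@H]1C(=O)N[C@H]1CCCNC1)c1cc(-c2ccc(Cl)cc2)on1` gives 2.1

Compound 3 stands highest of the three, clear of both others: the steps are a number 0.80 log units higher from compound 1 to compound 3 (beyond the scatter) and a number 1.10 log units higher from compound 2 to compound 3 (beyond the scatter). The next compound, compound 4 `O=C(N[C@H]1CN(S(=O)(=O)c2ccccc2)C[C@@H]1C(=O)N[C@H]1CCCNC1)c1cc(-c2ccc(Cl)cc2Cl)on1`, is reached by chloro in place of hydrogen on an aromatic carbon. This is chloro in place of hydrogen on an aromatic carbon, ortho to a large group and meta to a chloro group, or 4-chlorophenyl to 2,4-dichlorophenyl.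

Among the measured compounds shown here, the closest precedent is the one measured step of the same kind, chloro in place of hydrogen on an aromatic carbon: a number 0.80 log units higher from compound 1 to compound 3 (beyond the scatter). The other two steps exchange the whole group on the carbonyl carbon and bear on this change only weakly: a number 0.30 log units lower from compound 1 to compound 2 (within the scatter) and a number 1.10 log units higher from compound 2 to compound 3 (beyond the scatter). For the measured compounds named here, a single precedent gives no trend, and no measured compound carries a chloro ortho to a large group. A rise in this assay is therefore expected, somewhat smaller than the precedent, but with wide uncertainty. The expected step is a number 0.60 log units higher from compound 3 to compound 4 (beyond the scatter) by estimate. The estimate for compound 4 is 2.7 and the expected range runs from 2.3 to 3.1 as its ends.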

Compound 4, distribution coefficient: 2.5
The estimate for compound 4 lay 0.20 log units above the measured number, within the range that was stated.
By their numbers in this assay, from the lowest: compounds 2 and 1 (each within the scatter of the next); then compound 3; then compound 4.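

In this assay, chloro in place of hydrogen on an aromatic carbon, ortho to a large group and meta to a chloro group, still moves the number up, with a number 0.40 log units higher from compound 3 to compound 4 (beyond the scatter). Among the compounds shown here, this is the first reading at this position, and the step is smaller than the one measured for the chloro of the 4-chlorophenyl group, a number 0.80 log units higher from compound 1 to compound 3 (beyond the scatter). Across the whole change, 2,4-dichlorophenyl in place of phenyl gives a number 1.20 log units higher from compound 1 to compound 4 (beyond the scatter), so both chloro steps run in the same direction in these compounds, though nothing at hand speaks to why their sizes differ.

For the compounds shown here, open is whether a chloro ortho to a large group gives a step of this size with no chloro group meta to it, since the only reading at this position carries both. Going by these compounds alone, also open is how this assay responds at the same position to a different group, such as an amine, a carboxylic acid or a longer chain, and whether the chloro step holds with the other group on the carbonyl carbon, the one carried by compound 2.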